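Unsaturated Linker Restored on the Hydantoin Analogue

The compounds below may be only part of what the source reports. "The series", "measured", "known", "first", "only" and "open" are said of these compounds alone.

Going by the values given here, in a functional assay on CHO cells for antagonist activity at prostaglandin E2 receptor EP3 subtype (Homo sapiens), read by cAMP accumulation, with a stated time of 30 min (a higher number here means a weaker inhibitor, a lower number a stronger inhibitor), compound 2 `CC(C)C(c1ccc(-c2ccc3cccc(F)c3c2)[nH]c1=O)C1C(=O)NC(=O)N1C` gives 320 nM, the highest of the two numbers recorded; its only neighbour, compound 1 `C/C(=C1/OC(=O)NC1=O)C(c1ccc(-c2ccc3cccc(F)c3c2)[nH]c1=O)C(C)C`, gives 39 nM. The step of an 8.2-fold higher number from compound 1 to compound 2 (0.91 log units; beyond the scatter) thus runs from a ring joined through an exocyclic double bond to a ring joined directly at a saturated carbon, and it weakens inhibition.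

Compound 3 `CC(C)C(/C=C1/C(=O)NC(=O)N1C)c1ccc(-c2ccc3cccc(F)c3c2)[nH]c1=O` is the unmeasured analogue: a group of 9 heavy atoms (5 carbon, 2 nitrogen, 2 oxygen; one five-membered non-aromatic ring with 2 hetero atoms) in place of a group of 8 heavy atoms (4 carbon, 2 nitrogen, 2 oxygen; one five-membered non-aromatic ring with 2 hetero atoms), on a saturated chain carbon bound to an aromatic carbon and a saturated chain carbon. It keeps the 3-methyl-2,5-dioxoimidazolidin-4-yl ring of compound 2 but reintroduces a double bond into the link, a feature that compound 1 also carries. Among the compounds with values here, only the step from compound 1 to compound 2 bears on this change; it was modest yet beyond the scatter. Because that step an 8.2-fold higher number from compound 1 to compound 2 (0.91 log units; beyond the scatter) ran the other way, compound 3 is expected to lower the number by about a 4.0-fold lower number from compound 2 to compound 3 (0.60 log units; beyond the scatter), though the added carbon in the link leaves room for it to fall short of compound 1. Compound 3 is therefore estimated at 80 nM, within a range of 25 nM to 250 nM.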

Compound 3, half-maximal inhibitory concentration: 11 nM
Compound 3: middle estimate off by 7.3-fold (0.86 log units), on the high side; measured number outside the range, below it.
By their numbers in this assay, from the lowest: compound 3; then compound 1; then compound 2.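

In this assay, at this saturated chain carbon bound to an aromatic carbon and a saturated chain carbon, the group of 9 heavy atoms, with 3 double bonds outside aromatic rings against 2 in the 3-methyl-2,5-dioxoimidazolidin-4-yl group it replaces, gives a 29-fold lower number from compound 2 to compound 3 (1.46 log units; beyond the scatter), the largest step among these compounds. Going by these compounds alone, the earlier pair showed only that a change at this place could weaken inhibition, whereas the new result also goes past compound 1, with a 3.5-fold lower number from compound 1 to compound 3 (0.55 log units; beyond the scatter), which makes compound 3 the strongest inhibitor of the three. No measurement at hand accounts for the size of either step.

The step from compound 2 to compound 3 adds a carbon and a double bond together, so these compounds cannot tell the contribution of one from that of the other; a saturated two-carbon link carrying the same ring would separate them. Also open, on these data alone, are the opposite geometry of the double bond and whether a carboxylic acid or an amine in place of this ring would keep inhibition at this level.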